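The source may hold more compounds than are shown below. What is called first, only, known or untested is meant among the compounds shown, and "the series" means these compounds.

Compound 1 `c1c[nH]c(CN2CCN(CCCc3c[nH]c4ccc(-n5cnnc5)cc34)CC2)n1` and compound 2 `CN(C)C(=O)C(c1ccccc1)N1CCN(CCCc2c[nH]c3ccc(-n4cnnc4)cc23)CC1` share the same core and differ only in the group attached to the amine nitrogen in the ring. Within the data shown here, in a functional assay on CHO cells for activation of 5-hydroxytryptamine receptor 1D (Homo sapiens), read by GTPgammaS binding (a higher number here means that more compound is needed for the effect, a lower number that less compound is needed), compound 1 gives 2 nM, the higher of the two numbers known so far, while compound 2 gives 0.8 nM, a difference that lies beyond the usual scatter of this assay. Compound 3 `c1cnc(N2CCN(CCCc3c[nH]c4ccc(-n5cnnc5)cc34)CC2)nc1` is a further variation on compound 1: the change is pyrimidin-2-yl in place of (1H-imidazol-2-yl)methyl on an amine nitrogen in a ring. Among the measured compounds shown here, no measured pair shows what such a swap does, so the expectation rests only on the two values known. Since compound 2 with a quite different group at this position still gives 0.8 nM, the step from compound 1 to compound 3 is expected to be small, at most a modest rise, estimated as a 1.5-fold higher number from compound 1 to compound 3 (0.18 log units; within the scatter). Compound 3 is therefore expected to give about 3 nM in this assay, most likely between 0.8 nM and 12 nM.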

Compound 3, half-maximal effective concentration: 0.6 nM
The estimate for compound 3 lay 5.0-fold (0.70 log units) above the measured number; measured number outside the range, below it.
By their numbers in this assay, from the lowest: compounds 3 and 2 (each within the scatter of the next); then compound 1.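

In this assay, putting pyrimidin-2-yl in place of (1H-imidazol-2-yl)methyl on the amine nitrogen in the ring gives a 3.3-fold lower number from compound 1 to compound 3 (0.52 log units; beyond the scatter), which shows that the number at this position can shift beyond the scatter with a single change of group. The two groups match in heavy atoms, carbon and nitrogen, yet they differ in ring size and in their hydrogen-bond donors and acceptors, and the compounds shown cannot tell which of these differences matters. Nothing at hand explains the step.

From the compounds shown here alone, what remains open is whether the gain comes from the ring itself or from losing the methyl link. A pyrimidin-2-ylmethyl group would test that link directly, while a plain phenyl ring would show whether the ring nitrogens matter at all.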